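The compounds below may be only part of what the source reports. "The series", "measured", "known", "first", "only" and "open" are said of these compounds alone.

Measured so far in an ADME assay on Huh-7 cells (Homo sapiens) for cytotoxicity, read by MTT assay, with a stated time of 72 h; on this read-out lower numbers stand for higher toxicity in this test and higher numbers for lower toxicity in this test:
Compound 1 `Nc1c(C(=O)O)sc2nc(-c3ccccc3)cc(C(F)(F)F)c12` — in this assay compound 1 gives > 20000 nM, a limit of the assay.
Compound 2 `Nc1c(C(=O)N2CCCCC2)sc2nc(-c3ccccc3)cc(C(F)(F)F)c12` — in this assay compound 2 gives > 20000 nM, again a limit.
Compound 3 `Nc1c(C(=O)NC2CCCC2)sc2nc(-c3ccccc3)cc(C(F)(F)F)c12` — in this assay compound 3 gives > 20000 nM, also a limit.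

Compound 3 therefore stands where every measured compound of the series stands: at the limit of > 20000 nM in this assay, at which 3 of the 3 values shown sit. The steps a step that the two limits leave unreadable from compound 1 to compound 2, a step that the two limits leave unreadable from compound 1 to compound 3 and a step that the two limits leave unreadable from compound 2 to compound 3 are all unreadable, since both ends of each sit at the limit.

Compound 4 `Nc1c(C(=O)NCc2ccccc2)sc2nc(-c3ccccc3)cc(C(F)(F)F)c12` differs from compound 3 by benzyl in place of cyclopentyl on an amide-type nitrogen. Going by the values given here, no measured step reads on this change; the three limits only show that the hydroxy, piperidin-1-yl and cyclopentylamino variants all stay at the limit. The expected step that the limit leaves unreadable from compound 3 to compound 4 is accordingly none beyond the scatter. For compound 4 the estimate in this assay is 30000 nM, range 12000 nM to 100000 nM, most likely reported as a limit again.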

Compound 4, half-maximal cytotoxic concentration: > 20000 nM
Compound 4: only a limit was reported; the forecaster's own chance of this, stated with the estimate: 80%; the middle value is on the limit's open side.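

In this assay compound 4 gives > 20000 nM, again a limit, so its steps from compound 1, compound 2 and compound 3 cannot be read. The compounds shown leave open whether any group on the carbonyl carbon gives a measurable value.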